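Swapping Ethoxy for Trifluoromethyl in a Cytotoxicity Series

The source may hold more compounds than are shown below. What is called first, only, known or untested is meant among the compounds shown, and "the series" means these compounds.

Compound 2 `CCOC(=O)CCCCCOc1cccc(CN(C(=O)c2ccc(-c3cccc(OCC)c3)cc2)C(C)C)c1` is a close relative of compound 1 `CCOC(=O)CCCCCOc1cccc(CN(C(=O)c2ccc(-c3cccc(Oc4ccccc4)c3)cc2)C(C)C)c1`. In an ADME assay on HEK293 cells (Homo sapiens) for cytotoxicity, read by CellTiter-Glo and resazurin assay, with a stated time of 72 h (a lower number here means that less compound is needed, a higher number that more compound is needed for the effect), compound 2 gives > 22300 nM, a limit of the assay. Compound 1 gives > 19600 nM, likewise a limit. The step that the two limits leave unreadable from compound 1 to compound 2 therefore cannot be read, and no bearing on direction or size follows from it.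

Compound 3 `CCOC(=O)CCCCCOc1cccc(CN(C(=O)c2ccc(-c3cccc(C(F)(F)F)c3)cc2)C(C)C)c1` differs from compound 2 by trifluoromethyl in place of ethoxy on an aromatic carbon. Since both measured values sit at limits, the step that the limit leaves unreadable from compound 2 to compound 3 is expected to be small and compound 3 is expected to stay near a limit too. Compound 3 is estimated at 25000 nM, within a range from 12000 nM to 60000 nM.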

Compound 3, half-maximal effective concentration: > 26000 nM
Compound 3: a limit, no number (the forecaster's own chance of this, stated with the estimate: 70%); middle value at least 1.0-fold (0.01 log units) away from the limit.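

Among these compounds, compound 1, compound 2 and compound 3 all give limits rather than numbers in this assay, so no step among them can be read. Going by these compounds, the concentration at which any of them reaches the half-maximal effect stays open.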